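Pyridin-4-ylmethyl oxime ether: expected whole-blood inhibition

The source may report more compounds than this note shows. Statements on the series, on what has been measured and on what is new or still open speak of the compounds shown alone.

Measured so far:
compound 1 `OC1O[C@H](CO/N=C2\CCc3cc(Sc4cc(F)cc(C5CCOCC5)c4)ccc32)[C@H](O)[C@H](O)[C@H]1O` — > 2500 nM
compound 2 `CO/N=C(\C)c1ccc(Sc2cc(F)cc(C3CCOCC3)c2)cc1` — 110 nM
compound 3 `C/C(=N\OCCSc1nnnn1C)c1ccc(Sc2cc(F)cc(C3CCOCC3)c2)cc1` — 120 nM

In a functional assay (blood) for inhibition, with Homo sapiens as the target (on this read-out higher numbers stand for weaker inhibition and lower numbers for stronger inhibition), compound 1 reaches only the assay limit of > 2500 nM, a limit rather than a number (the limit of > 2500 nM in this assay, at which 1 of the 3 values shown sits). Compound 2 gives 110 nM in this assay, and compound 3 gives 120 nM in this assay; these two numbers sit within the scatter of each other, so neither is placed above the other.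

Compound 4 `C/C(=N\OCc1ccncc1)c1ccc(Sc2cc(F)cc(C3CCOCC3)c2)cc1` differs from compound 2 by pyridin-4-yl in place of hydrogen on a saturated chain carbon bound to an oxygen. Going by the values given here, the one measured step at the same place, a 1.1-fold higher number from compound 2 to compound 3 (0.04 log units; within the scatter), stayed within the scatter. The step to compound 4 is therefore expected to stay within the scatter as well, with a 1.1-fold higher number from compound 2 to compound 4 (0.04 log units; within the scatter) as the estimate. Compound 4 is expected to give 120 nM in this assay, between 50 nM and 300 nM.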

Compound 4, half-maximal inhibitory concentration: 300 nM
Estimate against measurement, compound 4: 2.5-fold (0.40 log units) below; measured number inside the range.
By their numbers in this assay, from the lowest: compounds 2 and 3 (each within the scatter of the next); then compound 4. At a limit, above all of these: compound 1.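

In this assay pyridin-4-yl on the saturated chain carbon bound to an oxygen gives a 2.7-fold higher number from compound 2 to compound 4 (0.44 log units; beyond the scatter) and, in place of ((1-methyl-1H-tetrazol-5-yl)sulfanyl)methyl, gives a 2.5-fold higher number from compound 3 to compound 4 (0.40 log units; beyond the scatter) as well. Going by these compounds alone, the earlier step at this place stayed within the scatter, so this change is the first to show that what enters here can modestly weaken inhibition. Nothing shown accounts for this step.

Left open is how an amine or a carboxylic acid would read at this place. As far as these compounds go, it is also open whether a longer chain carrying pyridin-4-yl would give weaker or stronger inhibition than compound 4 does.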